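Three Limits and an Untested Methylsulfanyl Neighbour

The source may report more compounds than this note shows. Statements on the series, on what has been measured and on what is new or still open speak of the compounds shown alone.

In a functional assay on K562 cells (Homo sapiens) for antiproliferative activity, read by MTT assay, with a stated time of 72 h (a lower number here means a stronger inhibitor, a higher number a weaker inhibitor), compound 1 `COc1cc(-n2ncnc2-c2cccc(Cl)c2)cc(OC)c1OC` gives > 10000 nM as a limit, not a number. Compound 2 `COc1cc(-n2ncnc2-c2cccc(F)c2)cc(OC)c1OC` gives > 10000 nM as a limit as well. Compound 3 `COc1ccccc1-c1ncnn1-c1cc(OC)c(OC)c(OC)c1` gives > 10000 nM as a limit too, so it stands where the other two stand, with no number of its own.

Compound 4 `COc1cc(-n2ncnc2-c2ccc(SC)cc2)cc(OC)c1OC` has 4-(methylsulfanyl)phenyl in place of 2-methoxyphenyl on an aromatic carbon and is otherwise the same as compound 3.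

The measured steps that touch this same group are a step that the two limits leave unreadable from compound 1 to compound 3 and a step that the two limits leave unreadable from compound 2 to compound 3 and neither has a size that can be read. The remaining one, a step that the two limits leave unreadable from compound 1 to compound 2, adds no size either. All the series offers is the limit of > 10000 nM in this assay, at which 3 of the 3 values shown sit, and nothing finer.

The safest expectation is therefore that compound 4 stays near that limit, and any readable value would have to lie on the stronger side of it. The estimated change is an at least 1.2-fold lower number from compound 3 to compound 4 (0.09 log units; that floor lies within the scatter) and it is expected to point, if anywhere, toward stronger inhibition. In this assay compound 4 is estimated at 8000 nM with 300 nM to 20000 nM as the expected span.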

Compound 4, half-maximal inhibitory concentration: 340 nM
Compound 4: the middle estimate sits 24-fold (1.37 log units) above what was measured; low and high end bracket the measured number.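

The aryl group on this aromatic carbon, between two ring nitrogen atoms, can decide whether a compound reads as an inhibitor at all in this assay: 4-(methylsulfanyl)phenyl in place of 2-methoxyphenyl gives an at least 29-fold lower number from compound 3 to compound 4 (1.46 log units; beyond the scatter), in place of 3-fluorophenyl it gives an at least 29-fold lower number from compound 2 to compound 4 (1.46 log units; beyond the scatter), and in place of 3-chlorophenyl it gives an at least 29-fold lower number from compound 1 to compound 4 (1.46 log units; beyond the scatter). For the compounds shown here, all three sizes are floors, and they are the first sizes available at this position, as the steps among compound 1, compound 2 and compound 3 cannot be read. Compound 4 is the only compound shown with an actual number, and the other three stay at a limit: the limit of > 10000 nM in this assay, at which 3 of the 4 values shown sit.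

Compound 4 differs from the other three both in carrying sulfur and in the place of its group on the phenyl ring, and the compounds shown do not separate these two features. They also leave open how a longer chain on the sulfur, such as ethylsulfanyl, or an amine in place of the methylsulfanyl group would read in this assay.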